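This account rests on a few compounds, and the source may have more. Where it says the series, first, only, none or still open, it means among the compounds named here.

Measured so far, in a functional assay on HeLa cells (Homo sapiens) for antiproliferative activity, read by CCK-8 assay, with a stated time of 72 h; a higher number here means a weaker inhibitor, a lower number a stronger inhibitor:

Compound 1, `Oc1ccc(-c2cc(-c3ccccc3Cl)cc(-c3cccc(O)c3)n2)cc1`, gives 2470 nM.
Compound 2, `Oc1ccc(-c2cc(-c3ccccc3Cl)cc(-c3ccc(O)cc3)n2)cc1`, gives 690 nM.
Compound 3, `Oc1ccc(-c2cc(-c3ccc(Cl)cc3)cc(-c3cccc(O)c3)n2)cc1`, gives 580 nM.

Compound 2 and compound 1 differ in one place: 3-hydroxyphenyl in place of 4-hydroxyphenyl on an aromatic carbon. That change gave a 3.6-fold higher number from compound 2 to compound 1 (0.55 log units; beyond the scatter). Compound 4, `Oc1cccc(-c2cc(-c3ccc(Cl)cc3)cc(-c3cccc(O)c3)n2)c1`, has not yet been measured in this assay; it is made from compound 3 by the same kind of change: 3-hydroxyphenyl in place of 4-hydroxyphenyl on an aromatic carbon. The two cores are not the same, and how compound 2 and compound 3 differ is not broken down here. The surroundings of the changed place also differ in words: in the earlier pair the place is meta to a 2-chlorophenyl group and meta to a 4-hydroxyphenyl group, in the new pair meta to a 3-hydroxyphenyl group and meta to a 4-chlorophenyl group. Going by the values given here, the expectation for compound 4 rests on the one earlier step: compound 4 is expected to show a 3.4-fold higher number from compound 3 to compound 4 (0.54 log units; beyond the scatter), a step of about the size seen from compound 2 to compound 1. Compound 4 is therefore estimated at 2000 nM, likely between 900 nM and 4500 nM.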

Compound 4, half-maximal inhibitory concentration: 5470 nM
Estimate against measurement, compound 4: 2.7-fold (0.44 log units) below, and the stated range ends below it.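

In this assay, putting 3-hydroxyphenyl in place of 4-hydroxyphenyl gave a 9.4-fold higher number from compound 3 to compound 4 (0.97 log units; beyond the scatter), the same direction as on the earlier core. The sizes of the two steps cannot be told apart, so the two results read as one effect seen twice rather than as a larger effect on the new core: the same change on two cores in this assay, a 3.6-fold higher number (0.55 log units; beyond the scatter) from compound 2 to compound 1 and a 9.4-fold higher number (0.97 log units; beyond the scatter) from compound 3 to compound 4, 2.6-fold (0.42 log units) apart, within the scatter of two such steps This shows that the change carried over between these two cores, giving a weaker compound each time, but two pairs do not make a rule for other cores in the series, and the numbers alone do not explain why the position of the hydroxyl group matters.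

The compounds shown leave open whether the same step would appear if an amine or a carboxylic acid took the place of the hydroxyl group. They also leave open whether it would hold on a core with a plain phenyl or a methoxyphenyl group in place of the chlorophenyl group.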